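A thiazoline ring in place of phenyl on a galloyl amide

This account rests on a few compounds, and the source may have more. Where it says the series, first, only, none or still open, it means among the compounds named here.

Compound 1 `O=C(Nc1ccccc1)c1cc(O)c(O)c(O)c1` is an amide of a trihydroxybenzoyl group with an aniline. In an assay on isolated protein for inhibition of DNA topoisomerase 1 (Homo sapiens) (on this read-out lower numbers stand for stronger inhibition and higher numbers for weaker inhibition), compound 1 returns only a limit, > 100000 nM, so its true value is not known. This is the point described by the limit of > 100000 nM in this assay, at which 1 of the 2 values shown sits. Compound 2 `O=C(Nc1cccc(NC(=O)c2ccc(O)c(O)c2)c1)c1ccc(O)c(O)c1` joins two dihydroxybenzoyl amides through a shared aromatic diamine, and in this assay compound 2 gives a measured value of 10000 nM. Compound 3 `O=C(NC1=NCCS1)c1cc(O)c(O)c(O)c1` carries the same core as compound 1 but differs by a group of 5 heavy atoms (3 carbon, 1 nitrogen, 1 sulfur; one five-membered non-aromatic ring with 2 hetero atoms) in place of a group of 6 heavy atoms (6 carbon; one six-membered aromatic ring of carbon only), on an amide-type nitrogen; in words, a group of 5 heavy atoms (3 carbon, 1 nitrogen, 1 sulfur; one five-membered non-aromatic ring with 2 hetero atoms) replaces a group of 6 heavy atoms (6 carbon; one six-membered aromatic ring of carbon only) on an amide-type nitrogen. With compound 1 known only as a limit, the expected step from compound 1 to compound 3 is estimated as an at least 1.6-fold lower number from compound 1 to compound 3 (0.22 log units; that floor lies within the scatter), and the estimate for compound 3 in this assay is 60000 nM, between 10000 nM and 300000 nM.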

Compound 3, half-maximal inhibitory concentration: 34400 nM
The estimate for compound 3 lay 1.7-fold (0.24 log units) above the measured number; the measured number falls inside the stated range.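

In this assay, the amide-type nitrogen proves sensitive to what it carries: replacing phenyl with the five-membered non-aromatic ring with 2 hetero atoms gives an at least 2.9-fold lower number from compound 1 to compound 3 (0.46 log units; beyond the scatter). Within the data shown here, this is the first evidence on this change, and it shows that a trihydroxybenzoyl amide can reach a measurable value in this assay when the phenyl is gone. Going by these compounds, the true size of the step remains unknown, and only its floor can be read, because the value of compound 1 is a limit: the limit of > 100000 nM in this assay, at which 1 of the 3 values shown sits.

A single replacement cannot show which feature of the new ring matters, whether its sulfur, its nitrogen or its lack of aromaticity. Still open, on these data alone, is how the same nitrogen would respond to a cyclohexyl ring, a pyridine ring or a longer alkyl chain.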